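From Sulfamoyl to Chloro on the Shared Core

The compounds below may be only part of what the source reports. "The series", "measured", "known", "first", "only" and "open" are said of these compounds alone.

Compound 1, `Cc1cnc(Nc2ccc(S(C)(=O)=O)cc2)nc1Nc1nc2ccccc2s1`, in a functional assay on PC-3 cells (Homo sapiens) for antiproliferative activity, read by MTT assay, with a stated time of 48 h (on this read-out lower numbers stand for stronger inhibition and higher numbers for weaker inhibition), gives > 50000 nM, which is a limit of the assay and not a number.
Compound 2, `Cc1cnc(Nc2ccc(S(N)(=O)=O)cc2)nc1Nc1nc2ccccc2s1`, in this assay gives > 50000 nM, again a limit of the assay.

Compound 2 therefore stands at the limit, as does compound 1; the step that the two limits leave unreadable from compound 1 to compound 2 cannot be read, because the limit of > 50000 nM in this assay, at which 2 of the 2 values shown sit, holds both values. The next change leaves the sulfonyl part of the molecule entirely: chloro in place of sulfamoyl on an aromatic carbon, giving compound 3, `Cc1cnc(Nc2ccc(Cl)cc2)nc1Nc1nc2ccccc2s1`. Within the data shown here, no measured step bears directly on chloro in place of sulfamoyl; the only step measured, from a methyl to an amino on the sulfonyl sulfur, lies hidden beneath the limit, so neither its size nor its direction is known. With both neighbours unresolved, the expectation for compound 3 can only lean on the fact that every value shown so far sits at the limit. Compound 3 is thus expected to give about 40000 nM in this assay, with a range from 8000 nM to 100000 nM. The step of an at least 1.2-fold lower number from compound 2 to compound 3 (0.09 log units; that floor lies within the scatter) is expected to stay within the scatter, though a readable number would itself be new information.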

Compound 3, half-maximal inhibitory concentration: > 50000 nM
Compound 3: a limit, no number; the forecaster's own chance of this, stated with the estimate: 60%; middle value at least 1.2-fold (0.09 log units) from the limit.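

In this assay compound 3 gives > 50000 nM, which is a limit of the assay and not a number. The steps to compound 3 from compound 1 and from compound 2 therefore cannot be read: the limit of > 50000 nM in this assay, at which 3 of the 3 values shown sit.

The compounds shown leave open whether methylsulfonyl, sulfamoyl and chloro differ at all in this assay, and whether any change on the shared core gives a readable number.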